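Hydroxy on the Benzyl Ring of a Trimethoxyphenyl Amide

This account rests on a few compounds, and the source may have more. Where it says the series, first, only, none or still open, it means among the compounds named here.

Compound 1 `COc1ccc(CN(C(=O)CSC(=S)N2CCN(C(=O)OC(C)(C)C)CC2)c2cc(OC)c(OC)c(OC)c2)cc1` is the reference point of this set. In a functional assay on KYSE-450 cells (Homo sapiens) for inhibition, read by CCK-8 assay, with a stated time of 48 h (on this read-out higher numbers stand for weaker inhibition and lower numbers for stronger inhibition), compound 1 gives 250 nM, the lowest number among the two numbers on record. Compound 2 `COc1ccc(CN(C(=O)CSC(=S)N2CCN(Cc3ccc(C(C)(C)C)cc3)CC2)c2cc(OC)c(OC)c(OC)c2)cc1` sits above it, with an 8.6-fold higher number from compound 1 to compound 2 (0.93 log units; beyond the scatter) following from 4-(tert-butyl)benzyl in place of tert-butoxycarbonyl on an amine nitrogen in a ring; compound 2 gives 2140 nM in this assay. Compound 3 `COc1ccc(CN(C(=O)CSC(=S)N2CCN(C(=O)OC(C)(C)C)CC2)c2ccc(OC)cc2)cc1` reached only a limit of this assay, > 20000 nM, where (the limit of > 20000 nM in this assay, at which 1 of the 3 values shown sits); the change 4-methoxyphenyl in place of 3,4,5-trimethoxyphenyl on an amide-type nitrogen gave an at least 80-fold higher number from compound 1 to compound 3 (1.90 log units; beyond the scatter).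

Compound 4 `COc1ccc(CN(C(=O)CSC(=S)N2CCN(C(=O)OC(C)(C)C)CC2)c2cc(OC)c(OC)c(OC)c2)cc1O` differs from compound 1 by hydroxy in place of hydrogen on an aromatic carbon. Neither measured step touches the benzyl ring: one alters the amine substituent on the ring, the other the aryl group on the amide-type nitrogen. No measured comparison therefore informs this change, and the account expects a step of a 1.3-fold lower number from compound 1 to compound 4 (0.10 log units; within the scatter), within the scatter, around the value of compound 1. Compound 4 is estimated at 200 nM, with a range from 60 nM to 800 nM.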

Compound 4, half-maximal inhibitory concentration: 76 nM
Beside the measured number, compound 4's estimate is 2.6-fold (0.42 log units) above it; measured number inside the range.
By their numbers in this assay, from the lowest: compound 4; then compound 1; then compound 2. At a limit, above all of these: compound 3.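

The 4-methoxybenzyl to 3-hydroxy-4-methoxybenzyl change is the only step shown on this ring, and in this assay it gives a 3.3-fold lower number from compound 1 to compound 4 (0.52 log units; beyond the scatter) beyond the scatter of repeated measurements. This place, ortho to a methoxy group and meta to a large group, therefore responds to substitution, and hydroxy lowers the number here, whereas both earlier steps, made elsewhere on compound 1, raised it. Nothing on record accounts for this drop, and its cause remains unknown.

The compounds shown leave open whether hydroxy is specifically required at this place, or whether an amino group, a fluoro group or an ethoxy group would give a similar number. They also leave open whether the same change would lower the number when made on compound 2 or compound 3.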